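Anilino-bis-thiazole series: methoxy for methyl step

The compounds below may be only part of what the source reports. "The series", "measured", "known", "first", "only" and "open" are said of these compounds alone.

Measured so far:
compound 1 `COc1ccc(Nc2nnc(Nc3nc(-c4ccc(Cl)cc4)cs3)s2)cc1` 300 mg/kg
compound 2 `Cc1ccccc1Nc1nnc(Nc2nc(-c3ccc([N+](=O)[O-])cc3)cs2)s1` 100 mg/kg
compound 3 `Cc1ccc(Nc2nnc(Nc3nc(-c4ccc([N+](=O)[O-])cc4)cs3)s2)cc1` 100 mg/kg

In a functional assay on the whole organism (strain albino) with Mus musculus as the target, in the maximal electroshock model, with a stated time of 4 h (on this read-out higher numbers stand for an effect only at larger amounts of compound and lower numbers for an effect already at smaller amounts), compound 3 gives 100 mg/kg, level with compound 2 and the lowest of the three numbers; compound 1 lies furthest, a gap beyond the scatter. Going by the values given here, the one measured step, no change at the digits printed from compound 2 to compound 3 (within the scatter), concerns a different change and carries no information on the present one. Compound 4 `COc1ccc(Nc2nnc(Nc3nc(-c4ccc([N+](=O)[O-])cc4)cs3)s2)cc1` differs from compound 3 by methoxy in place of methyl on an aromatic carbon. Among the compounds with values here, no measured step bears on this change; compound 1 also carries methoxy but differs in a second place, so its two values with compound 3 cannot be read as a step. The expected step of a 1.5-fold higher number from compound 3 to compound 4 (0.18 log units; within the scatter) is therefore set at none beyond the scatter, with the range widened toward compound 1. Compound 4 is estimated at 150 mg/kg (70 mg/kg to 320 mg/kg).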

Compound 4, minimum effective dose: 30 mg/kg
Beside the measured number, compound 4's estimate is 5.0-fold (0.70 log units) above it; the measured number lies below the stated range.
By their numbers in this assay, from the lowest: compound 4; then compounds 2 and 3 (each within the scatter of the next); then compound 1.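

In this assay, methoxy on the aromatic carbon para to a large group is the first change shown at this position to go beyond the scatter: a 3.3-fold lower number from compound 3 to compound 4 (0.52 log units; beyond the scatter). The comparison with the 2-methylphenyl analogue gives a 3.3-fold lower number from compound 2 to compound 4 (0.52 log units; beyond the scatter), so 4-methoxyphenyl stands apart from both methylphenyl groups. With methoxy held fixed, nitro in place of chloro on an aromatic carbon gives a 10-fold lower number from compound 1 to compound 4 (1.00 log units; beyond the scatter), so a second place in the series also responds.

No evidence at hand accounts for these steps. From the compounds shown here alone, whether ethoxy or an amine at this position would give a still lower number remains open.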